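Two Limits and an Untested Acetyl Chain

The source may hold more compounds than are shown below. What is called first, only, known or untested is meant among the compounds shown, and "the series" means these compounds.

Compound 1 `COc1cc(CCCCC(C)(C)O)oc(=O)c1C` gives > 200000 nM as a limit
Compound 2 `Cc1c(O)cc(CCCCC(C)C)oc1=O` gives > 200000 nM as a limit

In a functional assay on HepG2 cells (Homo sapiens) for cytotoxicity, read by MTT assay (a higher number here means a weaker inhibitor, a lower number a stronger inhibitor), compound 2 stands at > 200000 nM as a limit and not a number. Taken together, the two measured compounds show the limit of > 200000 nM in this assay, at which 2 of the 2 values shown sit, and no exact value. Compound 3 `CC(=O)C(C)CCCCc1cc(O)c(C)c(=O)o1` has not yet been measured. Its difference from compound 2 is acetyl in place of methyl on a saturated chain carbon bound to two saturated chain carbons with acetyl in place of methyl on a saturated chain carbon bound to two saturated chain carbons. Going by the values given here, no measured step shows what such a change does in this assay so no direction can be favoured, and no shift beyond the scatter is expected. The expected step that the limit leaves unreadable from compound 2 to compound 3 is accordingly small. The estimated value for compound 3 is 220000 nM with an expected range from 120000 nM to 400000 nM in this measurement.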

Compound 3, half-maximal inhibitory concentration: > 200000 nM
Compound 3 was reported as a limit (the forecaster's own chance of this, stated with the estimate: 80%); the middle value is on the limit's open side.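

Going by these compounds alone, compound 2 and compound 3 are both reported only as limits, and no step between them can be read. The compounds shown leave open what acetyl in place of methyl does to the value, and what exact value compound 1, compound 2 or compound 3 has.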